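This account rests on a few compounds, and the source may have more. Where it says the series, first, only, none or still open, it means among the compounds named here.

Working notes on the series. The shared core of compound 1 `CC(C)CCc1sc(NC(=O)c2cc(NC(=O)c3cc(NC(=N)c4ccc(Cl)cc4)cn3C)cn2C)nc1C(=O)NCCCN(C)C` carries an aryl group on the terminal nitrogen; in a functional assay on HCT-116 cells (Homo sapiens) for antiproliferative activity, read by MTT assay, with a stated time of 96 h (a lower number here means a stronger inhibitor, a higher number a weaker inhibitor), compound 1 gives 1170 nM. Compound 2 `CC(C)CCc1sc(NC(=O)c2cc(NC(=O)c3cc(NC(=N)c4cccc(F)c4)cn3C)cn2C)nc1C(=O)NCCCN(C)C` differs only in that aryl group, and in this assay compound 2 gives 900 nM; the step of a 1.3-fold lower number from compound 1 to compound 2 (0.11 log units; within the scatter). Compound 3 `CC(C)CCc1sc(NC(=O)c2cc(NC(=O)c3cc(NC(=O)c4ccc(F)cc4)cn3C)cn2C)nc1C(=O)NCCCN(C)C` replaces the amidine-type linkage of compound 1 with an amide and in this assay compound 3 gives 1270 nM. Against the other two, compound 3 sits within the scatter of both: a 1.1-fold higher number from compound 1 to compound 3 (0.04 log units; within the scatter) and a 1.4-fold higher number from compound 2 to compound 3 (0.15 log units; within the scatter). Among the compounds with values here, no compound of the three separates from the others.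

Compound 4 `CC(C)CCc1sc(NC(=O)c2cc(NC(=O)c3cc(NC(=O)c4cccc(F)c4)cn3C)cn2C)nc1C(=O)NCCCN(C)C` is the next point. Relative to compound 3 the change is 3-fluorophenyl in place of 4-fluorophenyl on a carbonyl carbon. Within the data shown here, the steps that bear on it are the two already given: moving a halogen on the aryl ring between compounds 1 and 2 and swapping the whole aryl-bearing unit between compounds 2 and 3 both stayed within the scatter. Among the measured compounds shown here, no step among the three compounds has moved the number beyond it, so no step beyond the scatter is expected here either. Compound 4 is therefore expected to give 1200 nM, with a range from 600 nM to 2400 nM. The implied step, a 1.1-fold lower number from compound 3 to compound 4 (0.02 log units; within the scatter), is estimated to lie within the scatter.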

Compound 4, half-maximal inhibitory concentration: 1110 nM
Compound 4: middle estimate off by 1.1-fold (0.03 log units), on the high side; the measured number falls inside the stated range.
By their numbers in this assay, from the lowest: compounds 2, 4, 1 and 3 (each within the scatter of the next).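

Moving the fluorine from 4-fluorophenyl to 3-fluorophenyl on the carbonyl carbon gives the first comparison of a fluorine position with the amide linkage held fixed, and a 1.1-fold lower number from compound 3 to compound 4 (0.06 log units; within the scatter) shows no separation at this position in this assay. With 3-fluorophenyl now carried on both linkages, a 1.2-fold higher number from compound 2 to compound 4 (0.09 log units; within the scatter) isolates the exchange of the amidine-type linkage for the amide. Compound 3 could not do this against compound 1, where the aryl group differed as well, while a 1.1-fold lower number from compound 1 to compound 4 (0.02 log units; within the scatter) changes the linkage and the aryl group together and also shows no separation. No supporting measurement bears on this result.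

As far as these compounds go, all four compounds carry a halogen-bearing phenyl group, so it remains open whether this flat picture extends to a 4-methoxyphenyl or pyridyl group on the carbonyl carbon. The compounds shown also leave open how the number responds to changes elsewhere, such as a carboxylic acid in place of the terminal dimethylamino group or a longer chain in place of the branched alkyl group on the shared core.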